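Ester to acid on the thiophene series: compound 4

A few compounds are considered here, and "the series" means these few. Any claim that something is new, unique, unknown or untested is made for them only; others in the source may bear on it.

Compound 1 `COC(=O)c1c(Nc2ccccc2)sc(C(=O)c2ccc(OC)cc2)c1C` is the reference of the set. In a functional assay, with a stated time of 150 min, tested at 30 ug/mL (a higher number here means a stronger effect of the compound at the concentration tested, a lower number a weaker effect), compound 1 gives 48.1%, the highest of the two numbers at hand. Compound 2 `COC(=O)c1c(Nc2ccc(F)cc2)sc(C(=O)c2ccc(OC)cc2)c1C`, which carries fluoro in place of hydrogen on an aromatic carbon, gives 23.3% in this assay, and the step of a number 24.8 percentage points lower from compound 1 to compound 2 (beyond the scatter) lies beyond the scatter. Compound 3 `COC(=O)c1c(Nc2ccc(Cl)cc2)sc(C(=O)c2ccc(OC)cc2)c1C` is reported as "not active" (no number reported) in this assay, without a number.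

Compound 4 `COc1ccc(C(=O)c2sc(Nc3ccccc3)c(C(=O)O)c2C)cc1` differs from compound 1 in one place: hydrogen in place of methyl on an oxygen next to a carbonyl group. Within the data shown here, the only measured step, that from compound 1 to compound 2, concerns the aromatic ring of the anilino group and says nothing about this position; no measured pair in the set changes the ester. The expectation therefore rests on the reference value alone and must be wide. On that basis the number for compound 4 is estimated at 25%, within a range from 0% to 55%. This estimate means a step of a number 23.1 percentage points lower from compound 1 to compound 4 (beyond the scatter), expected to fall in the direction of a weaker effect, though a result within the scatter of compound 1 cannot be excluded.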

Compound 4, a percentage reported as activity, at one concentration (the size of the read-out at that concentration, not a potency): 59.5%
Compound 4: middle estimate off by 34.5 percentage points, on the low side; measured number outside the range, above it.
By their numbers in this assay, from the lowest: compound 2; then compound 1; then compound 4.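

Methoxycarbonyl to carboxy is the first change at this position with a measured outcome: in this assay it gives a number 11.4 percentage points higher from compound 1 to compound 4 (beyond the scatter), so the read-out does not depend on the methyl on an oxygen next to a carbonyl group, and removing it raises the number rather than lowering it. Among these compounds, the two steps measured from compound 1 run in opposite directions, since the change on the anilino ring gives a number 24.8 percentage points lower from compound 1 to compound 2 (beyond the scatter), while the ester position yields a gain, though only this single pair speaks for the position and the two changes sit at different places on the core. The data at hand contain nothing that accounts for this rise.

The compounds shown leave open whether other groups at this position, such as an ethyl ester, a longer chain on the oxygen, a carboxamide or a nitrile, would hold or extend the gain seen with the carboxylic acid. They also leave open whether the same change carries over to the fluoro and chloro anilino analogues, compound 2 and compound 3, which are known here only as esters.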